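A few compounds are considered here, and "the series" means these few. Any claim that something is new, unique, unknown or untested is made for them only; others in the source may bear on it.

Compound 1 `COc1ccc2[nH]c(-c3cccc(F)c3)cc(=O)c2c1OC` and compound 3 `COc1ccc2[nH]c(-c3cccc(F)c3)cc(=O)c2c1O` share one core and differ by hydrogen in place of methyl on an oxygen on an aromatic ring. In a functional assay on Hep 3B2 cells (Homo sapiens) for cytotoxicity, read by MTT assay, with a stated time of 48 h (a higher number here means a weaker inhibitor, a lower number a stronger inhibitor), compound 1 gives 2600 nM. Compound 3 gives 70 nM in this assay, a step of a 37-fold lower number from compound 1 to compound 3 (1.57 log units; beyond the scatter). Compound 2 `COc1ccc2[nH]c(-c3ccc(F)cc3)cc(=O)c2c1OC` differs from compound 1 by 4-fluorophenyl in place of 3-fluorophenyl on an aromatic carbon. In this assay compound 2 gives > 20000 nM, which is a limit of the assay rather than a number. The step of an at least 7.6-fold higher number from compound 1 to compound 2 (0.88 log units; beyond the scatter) is known only as a bound because compound 2 sits at the limit of > 20000 nM in this assay, at which 1 of the 3 values shown sits. Compound 4 `COc1ccc2[nH]c(-c3ccc(F)cc3)cc(=O)c2c1O` carries the same change relative to compound 3, namely (4-fluorophenyl in place of 3-fluorophenyl on an aromatic carbon), in the same surroundings. For compound 4 the expected step is an 11-fold higher number from compound 3 to compound 4 (1.06 log units; beyond the scatter), resting on an at least 7.6-fold higher number from compound 1 to compound 2 (0.88 log units; beyond the scatter). Compound 4 is estimated at 800 nM, between 200 nM and 5000 nM.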

Compound 4, half-maximal inhibitory concentration: 11000 nM
Compound 4: the middle estimate sits 14-fold (1.14 log units) below what was measured; measured number above the stated range.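

In this assay, 4-fluorophenyl in place of 3-fluorophenyl pushes the number up on both cores, so the direction of this change carries over, and the new case gives a 160-fold higher number from compound 3 to compound 4 (2.20 log units; beyond the scatter). Whether its size carries over stays unsettled: the same change on two cores in this assay, an at least 7.6-fold higher number (0.88 log units; beyond the scatter) from compound 1 to compound 2 and a 160-fold higher number (2.20 log units; beyond the scatter) from compound 3 to compound 4; the limit leaves it open whether they differ. Hydrogen in place of methyl on the oxygen gives an at least 1.8-fold lower number from compound 2 to compound 4 (0.25 log units; that floor lies within the scatter), so the large drop seen with the 3-fluorophenyl group is not shown to repeat with the 4-fluorophenyl group: the same change on two cores in this assay, a 37-fold lower number (1.57 log units; beyond the scatter) from compound 1 to compound 3 and an at least 1.8-fold lower number (0.25 log units; that floor lies within the scatter) from compound 2 to compound 4; the limit leaves it open whether they differ.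

The compounds shown leave open how the numbers would move with an amine or a carboxylic acid on the phenyl ring in place of fluorine. They also leave open whether the same steps hold on any other core.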